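The source may hold more compounds than are shown below. What is called first, only, known or untested is meant among the compounds shown, and "the series" means these compounds.

Measured so far:
- compound 1, `COc1ccc(C(=O)Nc2nc3cc(OC)ccc3s2)cc1`: > 10 ug/mL
- compound 2, `COc1ccc2sc(NC(=O)c3ccc([N+](=O)[O-])cc3)nc2c1`: > 10 ug/mL

In a functional assay on SK-HEP1 cells (Homo sapiens) for antiproliferative activity, read by sulforhodamine B assay (a lower number here means a stronger inhibitor of growth, a higher number a weaker inhibitor of growth), compound 2 gives > 10 ug/mL, which is a limit of the assay and not a measured number. Compound 1 also reaches only a limit in this assay, > 10 ug/mL. The change between them, nitro in place of methoxy on an aromatic carbon, therefore yields a step that the two limits leave unreadable from compound 1 to compound 2. Both values sit at the limit of > 10 ug/mL in this assay, at which 2 of the 2 values shown sit, so there is no readable step to carry forward.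

Compound 3, `COc1ccc2sc(NC(=O)c3ccc(C(F)(F)F)cc3)nc2c1`, differs from compound 2 by trifluoromethyl in place of nitro on an aromatic carbon. For the measured compounds named here, the only measured step touching this position is unreadable, so no direction can be taken from it, and the size of a step that the limit leaves unreadable from compound 2 to compound 3 is an expectation resting on the limits alone. Compound 3 is expected to give about 15 ug/mL in this assay, within a range from 4 ug/mL to 60 ug/mL, most likely reported again as a limit.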

Compound 3, concentration for 50% growth inhibition: > 10 ug/mL
Compound 3 gave a limit, no number (the forecaster's own chance of this, stated with the estimate: 70%); the middle value lies beyond the limit too.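

For the compounds shown here, no step among compound 1, compound 2 and compound 3 can be read, since all three values are limits and not numbers: the limit of > 10 ug/mL in this assay, at which 3 of the 3 values shown sit. The compounds shown leave open whether methoxy, nitro or trifluoromethyl at this position changes growth inhibition at all, and in which direction.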